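The source may report more compounds than this note shows. Statements on the series, on what has been measured and on what is new or still open speak of the compounds shown alone.

Compound 1 `O=C(NC1CCC(=Cc2cccc(Oc3ccc(C(F)(F)F)cn3)c2)CC1)c1cccnc1` in an assay for inhibition of Fatty-acid amide hydrolase 1 (Rattus norvegicus), read by fluorescence, with stated times of 1 min and 50 min (a lower number here means a stronger inhibitor, a higher number a weaker inhibitor), gives 27.8 nM.
Compound 3 `O=C(NC1CCC(=Cc2cccc(Oc3ccc(C(F)(F)F)cn3)c2)CC1)c1cn[nH]c1` in this assay gives 64.6 nM.
Compound 2 `O=C(NC1CCC(=Cc2cccc(Oc3ccc(C(F)(F)F)cn3)c2)CC1)c1ccccn1` in this assay gives "not determined" (no result reported).

Compound 3 holds the higher of the two numbers; compound 1 sits lower, the step being a 2.3-fold higher number from compound 1 to compound 3 (0.37 log units; beyond the scatter). Compound 4 `Nc1ncc(C(=O)NC2CCC(=Cc3cccc(Oc4ccc(C(F)(F)F)cn4)c3)CC2)cc1Cl` differs from compound 3 in one place: 6-amino-5-chloropyridin-3-yl in place of 1H-pyrazol-4-yl on a carbonyl carbon. Going by the values given here, the one measured step that bears on this is a 2.3-fold higher number from compound 1 to compound 3 (0.37 log units; beyond the scatter), which swaps the same pyrazole ring for a pyridin-3-yl ring on the carbonyl carbon; compound 4 carries a pyridin-3-yl ring too, now with amino and chloro groups. A step back down of about that size is therefore expected, a 2.2-fold lower number from compound 3 to compound 4 (0.33 log units; beyond the scatter). Compound 4 is estimated at 30 nM, with a range from 10 nM to 90 nM.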

Compound 4, half-maximal inhibitory concentration: 52 nM
Estimate against measurement, compound 4: 1.7-fold (0.24 log units) below, and the stated range covers the measured number.
By their numbers in this assay, from the lowest: compounds 1, 4 and 3 (each within the scatter of the next, the first and the last beyond it).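

The position on the carbonyl carbon accepts a pyridine ring bearing amino and chloro groups: in this assay, the pyrazole exchange gives a 1.2-fold lower number from compound 3 to compound 4 (0.09 log units; within the scatter), and adding those groups to the plain pyridin-3-yl ring gives a 1.9-fold higher number from compound 1 to compound 4 (0.27 log units; within the scatter). Compound 4 therefore cannot be told apart from either neighbour, even though those two neighbours differ from each other beyond the scatter. No available evidence explains this result. Going by these compounds, the amino group and the chlorine appear only together here, so their separate contributions stay open, as does the outcome with a pyridin-3-yl ring carrying just one of them, or a methoxy group instead.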